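Bromo in place of amino on the shared core

The source may report more compounds than this note shows. Statements on the series, on what has been measured and on what is new or still open speak of the compounds shown alone.

Three compounds share one core. Compound 1 `Nc1ccc2sc(NC(=S)NC(=O)c3ccccc3)nc2c1` gives 38600 nM in a functional assay on MCF7 cells (Homo sapiens) for cytotoxicity, read by MTT assay, with a stated time of 24 h; a higher number here means a weaker inhibitor, a lower number a stronger inhibitor; compound 2 `Nc1ccc2sc(NC(=S)NC(=O)c3ccc([N+](=O)[O-])cc3)nc2c1` gives 33200 nM; compound 3 `CCCCC(=O)NC(=S)Nc1nc2cc(N)ccc2s1` gives 44700 nM. Compound 2 has the smallest of the three numbers, but a 1.2-fold lower number from compound 1 to compound 2 (0.07 log units; within the scatter) and a 1.2-fold higher number from compound 1 to compound 3 (0.06 log units; within the scatter) both lie within the scatter, so the three are not separated. Compound 4 `O=C(NC(=S)Nc1nc2cc(Br)ccc2s1)c1ccc([N+](=O)[O-])cc1` differs from compound 2 by bromo in place of amino on an aromatic carbon. Neither measured step touches this position; both concern the acyl side and neither moves the number beyond the scatter. Among the compounds with values here, no step therefore speaks for or against a change here, and the expectation is a number for compound 4 close to that of compound 2, with a 1.0-fold lower number from compound 2 to compound 4 (0.00 log units; within the scatter) expected to stay within the scatter. The estimate for compound 4 is 33000 nM, with a range from 12000 nM to 90000 nM.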

Compound 4, half-maximal inhibitory concentration: 32400 nM
For compound 4 the middle estimate is 1.0-fold (0.01 log units) above the measured one, and the stated range covers the measured number.
By their numbers in this assay, from the lowest: compounds 4, 2, 1 and 3 (each within the scatter of the next).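

The position on the aromatic carbon now has a step of its own: in this assay, a 1.0-fold lower number from compound 2 to compound 4 (0.01 log units; within the scatter), for bromo in place of amino. With the nitro-bearing acyl side held fixed, this carbon tolerates the loss of the amino group's hydrogen-bond donor and acceptor without leaving the scatter. No measured evidence bears on why this change leaves the number in place.

On these data alone, whether a carboxylic acid or a dimethylamino group on this carbon would also stay within the scatter remains open. So does whether bromo behaves the same way alongside the unsubstituted benzoyl or pentanoyl side.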